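This account rests on a few compounds, and the source may have more. Where it says the series, first, only, none or still open, it means among the compounds named here.

In a functional assay on the whole organism with Rattus norvegicus as the target (a lower number here means that less compound is needed, a higher number that more compound is needed for the effect), compound 1 `CCOCCOC(=O)C(=O)Nc1nc(-c2cc(Cl)no2)cs1` gives only a limit, > 30 mg/kg. Compound 2 `CCOCCOC(=O)C(=O)Nc1nc(-c2cc(-c3c(F)cccc3Cl)no2)cs1` also gives only a limit, > 30 mg/kg. Compound 3 `CCOCCOC(=O)C(=O)Nc1nc(-c2cc(C(=O)OCC)no2)cs1` gives a true number, 1.9 mg/kg. With 2-chloro-6-fluorophenyl in place of chloro, the result is a step that the two limits leave unreadable from compound 1 to compound 2. Ethoxycarbonyl in place of chloro gives an at least 15-fold lower number from compound 1 to compound 3 (1.19 log units; beyond the scatter), and ethoxycarbonyl in place of 2-chloro-6-fluorophenyl gives an at least 15-fold lower number from compound 2 to compound 3 (1.19 log units; beyond the scatter). Compound 4 `CCOCCOC(=O)C(=O)Nc1nc(-c2conc2C)cs1` carries 3-methyl-1,2-oxazol-4-yl in place of 3-chloro-1,2-oxazol-5-yl (3-methyl-1,2-oxazol-4-yl in place of 3-chloro-1,2-oxazol-5-yl on an aromatic carbon). For the measured compounds named here, it has no ethoxycarbonyl, the group behind the only large steps, so those steps bear on it only loosely. A small move to a lower number is expected, estimated as an at least 1.5-fold lower number from compound 1 to compound 4 (0.17 log units; that floor lies within the scatter). The expected value for compound 4 is 20 mg/kg, within an estimated range of 5 mg/kg to 60 mg/kg.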

Compound 4, dose for half-maximal effect: > 100 mg/kg
Compound 4: a limit, no number; the forecaster's own chance of this, stated with the estimate: 45%; middle value at least 5.0-fold (0.69 log units) from the limit.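

Compound 1 and compound 4 both give only limits in this assay, and the step between them cannot be read. The compounds shown leave open whether any group other than the ethoxycarbonyl of compound 3 gives a true number.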